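From hydroxy to methoxy: compound 3 to compound 4

The source may report more compounds than this note shows. Statements on the series, on what has been measured and on what is new or still open speak of the compounds shown alone.

Compound 1 `CO[C@@H]1[C@H]2OC(=O)C[C@H]2O[C@@H]1[C@@H](O)c1ccccc1` gives 12700 nM as a measured number
Compound 2 `CO[C@@H](c1ccccc1)[C@H]1O[C@@H]2CC(=O)O[C@@H]2[C@H]1O` gives > 100000 nM as a limit
Compound 3 `CO[C@H](c1ccccc1)[C@H]1O[C@@H]2CC(=O)O[C@@H]2[C@H]1O` gives > 100000 nM as a limit

All three values come from a functional assay on MCF7 cells (Homo sapiens) for inhibition, read by MTT assay, with a stated time of 72 h; on this read-out higher numbers stand for weaker inhibition and lower numbers for stronger inhibition.

Compound 3 stands at > 100000 nM and this is a limit of the assay, not a number.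

Compound 4 `CO[C@@H]1[C@H]2OC(=O)C[C@H]2O[C@@H]1[C@H](OC)c1ccccc1` arises from compound 3 through one change, (methyl in place of hydrogen on an oxygen on a saturated carbon), which is methyl in place of hydrogen on an oxygen on a saturated carbon, or hydroxy to methoxy.

Going by the values given here, the only measured step is a step that the two limits leave unreadable from compound 2 to compound 3 and it concerns configuration alone, as the fact that compounds 2 and 3 differ only in the configuration as drawn makes clear. It therefore gives no size for this change.

Among the compounds with values here, the only actual number is compound 1 at 12700 nM, so that value frames a loose expectation of stronger inhibition. Compound 4 may still stay at the limit.

The expected move is an at least 3.3-fold lower number from compound 3 to compound 4 (0.52 log units; beyond the scatter) as a rough estimate.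

For compound 4 the estimated value is 30000 nM, with an expected range from 5000 nM to 100000 nM and a real chance of another limit.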

Compound 4, half-maximal inhibitory concentration: > 100000 nM
Compound 4 ended at the assay's limit (the forecaster's own chance of this, stated with the estimate: 35%); at least 3.3-fold (0.52 log units) between middle value and limit.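

The step from hydroxy to methoxy, going from compound 3 to compound 4, cannot be read, because both values are limits and not numbers: the limit of > 100000 nM in this assay, at which 3 of the 4 values shown sit.

The compounds shown leave open whether this change alters inhibition at all, and by how much.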